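This account rests on a few compounds, and the source may have more. Where it says the series, first, only, none or still open, it means among the compounds named here.

Compound 1 `O=C1COCCN1c1ccc(C2CC(c3ccc([N+](=O)[O-])o3)=NO2)cn1`: 60.2%
Compound 2 `O=C1COCCN1c1ccc(C2CC(c3ccc([N+](=O)[O-])o3)=NO2)cc1F`: 70.8%

In an ADME assay on a cell-free system (plasma, Homo sapiens) for protein binding, read by LC-MS, with a stated time of 4 h, tested at 10 uM, compound 1 gives 60.2%, and compound 2 gives 70.8%. The two values lie within the scatter of each other, so compound 1 stands level with compound 2. Compound 3 `CN1CCN(c2ccc(C3CC(c4ccc([N+](=O)[O-])o4)=NO3)cn2)C(=O)C1` carries 4-methyl-2-oxopiperazin-1-yl in place of 3-oxomorpholin-4-yl on an aromatic carbon. Among the measured compounds shown here, no measured pair shows what this exchange does, so no shift beyond the scatter is expected in this assay, in either direction. The expected change is a 1.1-fold higher unbound fraction from compound 1 to compound 3 (0.05 log units; within the scatter). For compound 3 the estimate is 55%, with an expected range of 35% to 75%.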

Compound 3, plasma protein binding: 48.9%
The estimate for compound 3 lay 1.1-fold (0.06 log units) (unbound fraction) below the measured number; the range from low to high includes it.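

With 4-methyl-2-oxopiperazin-1-yl in place of 3-oxomorpholin-4-yl on this aromatic carbon, this assay shows a 1.3-fold higher unbound fraction from compound 1 to compound 3 (0.11 log units; within the scatter). Among the compounds shown here, this is the first measured exchange at this position, and it shows that this added ring nitrogen and methyl group, taken together, leave the read-out within the scatter. Nothing measured here speaks to the reason for this result. On these data alone, whether a carboxylic acid or an open-chain amine at this position would move the read-out beyond the scatter remains open. So does the outcome of the same exchange on the core of compound 2.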